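Swapping fluoro for cyano on the phenyl ring

This account rests on a few compounds, and the source may have more. Where it says the series, first, only, none or still open, it means among the compounds named here.

Compound 1 `CN(C)CCCCOC(=O)Nc1ccc(Cn2nc(-c3cncnc3)c3ccccc3c2=O)cc1`: 65300 nM
Compound 2 `CN(C)CCCCOC(=O)Nc1ccc(Cn2nc(-c3cccc(C(F)(F)F)c3)c3ccccc3c2=O)cc1`: 11600 nM
Compound 3 `CN(C)CCCCOC(=O)Nc1ccc(Cn2nc(-c3ccccc3F)c3ccccc3c2=O)cc1`: 52500 nM

All three share one core and differ only in the aromatic group attached to it; the numbers come from an ADME assay on Huh-7 cells (Homo sapiens) for cytotoxicity, read by MTT assay, with a stated time of 48 h; on this read-out lower numbers stand for higher toxicity in this test and higher numbers for lower toxicity in this test. Compound 3 stands second highest of the three: a 1.2-fold lower number from compound 1 to compound 3 (0.09 log units; within the scatter), whereas a 4.5-fold higher number from compound 2 to compound 3 (0.66 log units; beyond the scatter). Compound 4 `CN(C)CCCCOC(=O)Nc1ccc(Cn2nc(-c3ccccc3C#N)c3ccccc3c2=O)cc1` is not yet measured and carries cyano in place of fluoro on an aromatic carbon. For the measured compounds named here, no measured step makes this same change. The two steps that alter this aryl group, a 5.6-fold lower number from compound 1 to compound 2 (0.75 log units; beyond the scatter) and a 1.2-fold lower number from compound 1 to compound 3 (0.09 log units; within the scatter), show that such swaps move the number modestly or not at all. Without a direct precedent, compound 4 is expected to stay close to compound 3, a 1.1-fold lower number from compound 3 to compound 4 (0.02 log units; within the scatter). For compound 4 the estimate in this assay is 50000 nM, ranging from 20000 nM to 120000 nM.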

Compound 4, half-maximal cytotoxic concentration: 90700 nM
The estimate for compound 4 lay 1.8-fold (0.26 log units) below the measured number; measured number inside the range.
By their numbers in this assay, from the lowest: compound 2; then compounds 3, 1 and 4 (each within the scatter of the next).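

In this assay, cyano on the ring, ortho to a large group, stays within the scatter of fluoro (a 1.7-fold higher number from compound 3 to compound 4 (0.24 log units; within the scatter)) and of the pyrimidin-5-yl compound (a 1.4-fold higher number from compound 1 to compound 4 (0.14 log units; within the scatter)). Only compound 2 stands clearly apart (a 7.8-fold higher number from compound 2 to compound 4 (0.89 log units; beyond the scatter)), so two different groups at this place now give numbers that cannot be told apart. Nothing measured here explains this.

From the compounds shown here alone, it remains open whether an amine or a methoxy group at the same place would also stay within the scatter. Going by these compounds, it is also open whether the low number of compound 2 follows from the trifluoromethyl group itself or from where it sits on the ring.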